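This account rests on a few compounds, and the source may have more. Where it says the series, first, only, none or still open, it means among the compounds named here.

Of the compounds shown here, two have been measured so far, and neither has yielded a number. Going by the values given here, compound 1 `O=c1[nH]c2ccc(-c3csc(-c4ccc(Cl)cc4)n3)cc2o1` is the first. In an assay on isolated protein for inhibition of protein phosphatase 1D (Homo sapiens), read by malachite green (on this read-out higher numbers stand for weaker inhibition and lower numbers for stronger inhibition), compound 1 gives only a limit of the assay, < 20000 nM. Compound 2 `CCc1cc(F)ccc1-c1nc(-c2ccc3[nH]c(=O)oc3c2)cs1` is the second. In this assay compound 2 also gives only a limit of the assay, < 20000 nM. Compound 2 therefore stands exactly where every value shown stands: at the limit, with no measured number to set it against, which is what the limit of < 20000 nM in this assay, at which 2 of the 2 values shown sit, sums up. Compound 3 `COc1cc(F)ccc1-c1nc(-c2ccc3[nH]c(=O)oc3c2)cs1` has not yet been measured. It differs from compound 2 in a single place, (methoxy in place of ethyl on an aromatic carbon). Among the compounds with values here, no step between two measured numbers exists in this set, so there is no measured guide to how a change at this position shifts the read-out. Given (the limit of < 20000 nM in this assay, at which 2 of the 2 values shown sit), compound 3 is expected to land close to where compound 2 sits, and the step is estimated at a step that the limit leaves unreadable from compound 2 to compound 3, within the usual scatter. The estimate for compound 3 in this assay is 6000 nM, with a range from 1000 nM to 19000 nM.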

Compound 3, half-maximal inhibitory concentration: < 20000 nM
Compound 3: a limit, no number; the forecaster's own chance of this, stated with the estimate: 70%; the middle value lies beyond the limit too.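

No step can be read from compound 2 to compound 3, because each of the two gives only a limit and not a number: the limit of < 20000 nM in this assay, at which 3 of the 3 values shown sit.

The compounds shown leave open how strongly any of them inhibits the enzyme, and whether methoxy in place of ethyl on an aromatic carbon changes that inhibition at all.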